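The compounds below may be only part of what the source reports. "The series", "measured", "known", "first", "only" and "open" are said of these compounds alone.

Measured in an ADME assay on THP-1 cells (Homo sapiens) for cytotoxicity, read by MTT assay, with a stated time of 72 h; a lower number here means that less compound is needed, a higher number that more compound is needed for the effect:
- compound 1 `Cc1cc(-c2ccc3[nH]c(=O)nc(-c4ccccc4)c3c2)ccn1`: > 50000 nM (a limit)
- compound 2 `O=c1nc(-c2ccccc2)c2cc(-c3ccc(F)cc3)ccc2[nH]1`: > 50000 nM (a limit)
- compound 3 `O=c1nc(-c2ccccc2)c2cc(-c3cc[nH]n3)ccc2[nH]1`: > 50000 nM (a limit)

Compound 3 therefore has no exact number, only a limit of the assay. It stands with the other two compounds, as the data show (the limit of > 50000 nM in this assay, at which 3 of the 3 values shown sit).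

Compound 4 `O=c1nc(C2CCCCC2)c2cc(-c3cc[nH]n3)ccc2[nH]1` keeps the pyrazole-bearing structure of compound 3 but changes another group: cyclohexyl in place of phenyl on an aromatic carbon. In words, a cyclohexyl replaces the phenyl on an aromatic carbon.

The measured steps all change a different group, and none touches this phenyl. They are a step that the two limits leave unreadable from compound 1 to compound 2, a step that the two limits leave unreadable from compound 1 to compound 3 and a step that the two limits leave unreadable from compound 2 to compound 3. None has a readable size, so they give no direct measure for the new change. For the measured compounds named here, they show only that three different groups at that other place all leave the compounds at the limit.

No step beyond the usual scatter is therefore expected in this assay, and no direction can be given. The estimated change is a number no higher from compound 3 to compound 4 (the limit leaves the size open). For compound 4 the estimate is 50000 nM, with an expected range from 20000 nM to 100000 nM.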

Compound 4, half-maximal effective concentration: > 50000 nM
Compound 4 was reported as a limit (the forecaster's own chance of this, stated with the estimate: 75%); the middle value sits exactly at the limit.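

No step can be read from compound 3 to compound 4 in this assay, as each is reported only as a limit, and the other compounds stand there too: the limit of > 50000 nM in this assay, at which 4 of the 4 values shown sit.

The compounds shown leave open what the exact values are and whether cyclohexyl in place of phenyl changes them at all.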